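This account rests on a few compounds, and the source may have more. Where it says the series, first, only, none or still open, it means among the compounds named here.

Within the data shown here, compound 1 `CCOC(=O)C1=C(C)NC(=S)NC1c1cn(C(=O)CNc2ccc([N+](=O)[O-])c(Cl)c2)c2ccccc12` stands highest of the two compounds measured so far in a physicochemical assay for lipophilicity (a higher number here means a more lipophilic compound, a lower number a more polar compound), where compound 1 gives 3.4. Among the measured compounds shown here, compound 2 `CCOC(=O)C1=C(C)NC(=O)NC1c1cn(C(=O)CNc2ccccc2[N+](=O)[O-])c2ccccc12`, which differs from it in more than one place, gives in this assay 1.48, a gap beyond the usual scatter; the two values show only that compound 1 sits higher, not which of the differences carries the gap. Compound 3 `CCOC(=O)C1=C(C)NC(=S)NC1c1cn(C(=O)CNc2cccc([N+](=O)[O-])c2)c2ccccc12` has not yet been measured. It differs from compound 1 in one place: 3-nitrophenyl in place of 3-chloro-4-nitrophenyl on an amine nitrogen. The group that leaves carries a chlorine that the entering group lacks. For the measured compounds named here, no pair of measured compounds isolates this change, so its size must be estimated from the structures alone. In this assay the change is expected to produce a modest drop, a number 0.60 log units lower from compound 1 to compound 3 (beyond the scatter), beyond the scatter yet well short of the distance separating the two measured values. Compound 3 is therefore expected to give about 2.8 in this assay, within a range from 2.3 to 3.3.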

Compound 3, partition coefficient: 2.88
The estimate for compound 3 lay 0.08 log units below the measured number; the range from low to high includes it.
By their numbers in this assay, from the lowest: compound 2; then compound 3; then compound 1.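

Among these compounds, the measurement in this assay isolates a single change for the first time: 3-nitrophenyl in place of 3-chloro-4-nitrophenyl on an amine nitrogen gives a number 0.52 log units lower from compound 1 to compound 3 (beyond the scatter) on the shared core. The earlier pair differed in more than one place and could assign its gap to no single site, whereas this step shows that the group at this position alone can move the number beyond the scatter. Nothing measured here explains the size of this step.

The compounds shown leave open how a bromine or a methoxy group in place of the chlorine would read. They also leave open whether the same exchange would give a step of similar size on the core of compound 2, which carries a carbonyl in place of the thiocarbonyl.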